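The source may hold more compounds than are shown below. What is called first, only, known or untested is meant among the compounds shown, and "the series" means these compounds.

Measured compounds: compound 1 `CC(C)N1CCN(Cc2csc(N)c2C(=O)c2ccc(Cl)cc2)CC1` with 0%; compound 2 `Nc1scc(CN2CCN(C3CCCCCC3)CC2)c1C(=O)c1ccc(Cl)cc1` with 0%, both in an assay on CHO cells for displacement of a labelled ligand from adenosine receptor A1 (Homo sapiens), read by scintillation counting, with a stated time of 120 min, tested at 10 uM; on this read-out higher numbers stand for more inhibition at the one concentration tested (going by the name of the read-out) and lower numbers for less inhibition.

Compound 2 stands level with compound 1 at the digits shown; the step of no change at the digits printed from compound 1 to compound 2 (within the scatter) stayed within the scatter. Compound 3 `Nc1scc(CN2CCN(c3c(F)cccc3F)CC2)c1C(=O)c1ccc(Cl)cc1` differs from compound 2 by 2,6-difluorophenyl in place of cycloheptyl on an amine nitrogen in a ring. Going by the values given here, the one measured step at this same ring nitrogen, no change at the digits printed from compound 1 to compound 2 (within the scatter), brought no change within the scatter, so compound 3 is expected to show no step beyond the scatter, a number 2 percentage points higher from compound 2 to compound 3 (within the scatter). Compound 3 is therefore estimated at 2%, within a range from -8% to 15%.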

Compound 3, a percentage reported as inhibition, at one concentration (the size of the read-out at that concentration, not a potency): 1%
Beside the measured number, compound 3's estimate is 1 percentage points above it; low and high end bracket the measured number.
By their numbers in this assay, from the lowest: compounds 1, 2 and 3 (each within the scatter of the next).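

In this assay, going by these compounds alone, 2,6-difluorophenyl brings an aromatic ring onto this amine nitrogen in a ring, where the earlier compounds carried only isopropyl and cycloheptyl. Even so, the steps of a number 1 percentage points higher from compound 2 to compound 3 (within the scatter) and a number 1 percentage points higher from compound 1 to compound 3 (within the scatter) stay within the scatter, so swapping these carbon groups for this aromatic ring leaves the read-out level. No measurement at hand explains this result.

Going by these compounds, it remains open whether another group on this nitrogen, such as benzyl, acetyl or a chain ending in a carboxylic acid, would give a reading clear of the scatter. Changes elsewhere on the shared core also remain open.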